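Turning a Ligand Into Its Mirror Image

The source may report more compounds than this note shows. Statements on the series, on what has been measured and on what is new or still open speak of the compounds shown alone.

Compound 1, `c1ccc(CCCCNCC[C@@H]2CCC[C@H](c3ccccc3)O2)cc1`: 15 nM
Compound 2, `CN(C)CC[C@H]1CCC[C@@H](c2ccccc2)O1`: 217 nM
Compound 3, `c1ccc([C@H]2CCC[C@@H](CCN3CCCC3)O2)cc1`: 60 nM

These three compounds were tested in an assay on membranes from brain for displacement of a labelled ligand from Sigma non-opioid intracellular receptor 1 (Cavia porcellus), read by scintillation counting, with a stated time of 120 min; a higher number here means a weaker inhibitor, a lower number a stronger inhibitor. Compound 1 gives 15 nM, the lowest number of the three, so it is the strongest inhibitor among them. Compound 3 gives 60 nM, a gap that lies beyond the usual scatter, and compound 2 gives 217 nM, further away still. All three share the same core and differ only in what hangs on the nitrogen.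

Compound 4, `c1ccc(CCCCNCC[C@H]2CCC[C@@H](c3ccccc3)O2)cc1`, has not yet been measured. It is the mirror image of compound 1: the two compounds have the same atoms and bonds and differ only in configuration as drawn: 2 of 2 stereo elements differ (all stereocentres are inverted: mirror images); a stereocentre at a saturated ring carbon is drawn S in compound 1 and R in compound 4; a stereocentre at a saturated ring carbon is drawn R in compound 1 and S in compound 4. For the measured compounds named here, no pair of measured compounds shows how this assay answers to a mirror image, so there is no measured step to lean on. Two mirror images may bind alike or quite differently; without a measured precedent, a moderate loss beyond the scatter is the expectation, while a retained value cannot be ruled out. Compound 4 is therefore expected to give about 45 nM, with a range from 10 nM to 250 nM. That estimate means an expected step of a 3.0-fold higher number from compound 1 to compound 4 (0.48 log units; beyond the scatter).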

Compound 4, inhibition constant: 29 nM
Estimate against measurement, compound 4: 1.6-fold (0.19 log units) above; low and high end bracket the measured number.
By their numbers in this assay, from the lowest: compounds 1 and 4 (each within the scatter of the next); then compound 3; then compound 2.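

In this assay, inverting both stereocentres at the saturated ring carbons gives a 1.9-fold higher number from compound 1 to compound 4 (0.29 log units; within the scatter), the first measured view of how this assay answers to a mirror image. Whatever separates the two numbers can come from one source only: the fact that compounds 1 and 4 differ only in the configuration as drawn. For this pair, then, the drawn configuration leaves the reading within the usual scatter, so the assay does not tell these two mirror images apart, and this holds for this one pair only.

Whether the mirror images of compound 2 and compound 3 would stay as close is open, as is the effect of inverting just one of the two stereocentres. Also open, as far as these compounds go, is how a compound with a piperidine as its amine, or with a longer chain on the nitrogen, would answer to the same inversion.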